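This account rests on a few compounds, and the source may have more. Where it says the series, first, only, none or still open, it means among the compounds named here.

Measured in a functional assay on K562 cells (Homo sapiens) for inhibition; a higher number here means a weaker inhibitor, a lower number a stronger inhibitor:
Compound 1 `COc1ccc(Cl)cc1-c1cc(Nc2ccc(Cl)cc2)nc(N)n1` gives 150 nM.
Compound 2 `CCOc1ccc(Br)cc1-c1cc(Nc2ccc(C(=O)NO)cc2)nc(N)n1` gives 700 nM.
Compound 3 `CCOc1ccc(Br)cc1-c1cc(Nc2ccc(/C(C)=N\O)cc2)nc(N)n1` gives < 50 nM, which is a limit.

Of the two numbered values, compound 1 holds the lower, at 150 nM, with compound 2 higher. Compound 4 `Nc1nc(Nc2ccc(Cl)cc2)cc(-c2cc(Cl)ccc2Cl)n1` carries chloro in place of methoxy on an aromatic carbon, ortho to a large group and para to a chloro group: chloro in place of methoxy on an aromatic carbon. Among the compounds with values here, the one measured step, an at least 14-fold lower number from compound 2 to compound 3 (1.14 log units; beyond the scatter), is large, but it does not touch the group exchanged here, so it bears on this change only weakly. In this assay, no step beyond the scatter is therefore expected, in either direction. The expected change is a 1.3-fold higher number from compound 1 to compound 4 (0.12 log units; within the scatter). For compound 4 the estimate is 200 nM, with an expected range of 60 nM to 700 nM.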

Compound 4, half-maximal inhibitory concentration: < 100 nM
Compound 4: only a limit was reported; the forecaster's own chance of this, stated with the estimate: 12%; middle value at least 2.0-fold (0.30 log units) from the limit.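

In this assay, chloro in place of methoxy gives an at least 1.5-fold lower number from compound 1 to compound 4 (0.17 log units; that floor lies within the scatter), so at this position, ortho to a large group and para to a chloro group, the methoxy is not needed for inhibition in this range. Compound 4 gives < 100 nM, which is a limit, so the step may lie within the scatter or beyond it. The earlier step, in another place, could not show this.

From the compounds shown here alone, how an amine or a longer chain such as propoxy would fare at this position stays open. So does whether the exchange would carry over to the core of compound 3.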